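A few compounds are considered here, and "the series" means these few. Any claim that something is new, unique, unknown or untested is made for them only; others in the source may bear on it.

Measured compounds:
compound 1 `Cc1ccc(S(=O)(=O)c2cnc3c(F)cccc3c2N2CCC(C)CC2)cc1` — in an assay on isolated protein for displacement of a labelled ligand from metabotropic glutamate receptor 5 (Homo sapiens), with a stated time of 60 min, tested at 1 uM (on this read-out lower numbers stand for less inhibition and higher numbers for more inhibition at the one concentration tested (going by the name of the read-out)), compound 1 gives 93%
compound 2 `Cc1ccc(S(=O)(=O)c2cnc3ccc(Cl)cc3c2N2CCC(C)CC2)cc1F` — compound 2 gives 68%
compound 3 `CC1CCN(c2c(S(=O)(=O)c3cc(F)cc(F)c3)cnc3c(F)cccc23)CC1` — compound 3 gives 9%

Compound 3 stands lowest of the three numbers shown in this assay: the nearest is compound 2, which lies higher by a margin beyond the scatter, and compound 1 lies higher still, also beyond the scatter.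

The step to be followed is from compound 3 to compound 4 `COc1ccc(S(=O)(=O)c2cnc3c(F)cccc3c2N2CCC(C)CC2)cc1`. The change is 4-methoxyphenyl in place of 3,5-difluorophenyl on a sulfonyl sulfur. For the measured compounds named here, only one measured step touches this position: a number 84 percentage points lower from compound 1 to compound 3 (beyond the scatter), a large fall when 3,5-difluorophenyl replaced 4-methylphenyl on the sulfonyl sulfur, with the rest of the core unchanged. Compound 4 carries the same core as compound 1 and compound 3 and returns a phenyl bearing a single group to the sulfonyl sulfur, so the step from compound 3 is expected to run opposite to that measured step and to be large in size, though the data give nothing on methoxy in particular, and a single step is thin ground.

For compound 4 in this assay the expected value is 75%, within 40% to 95%, meaning an estimated step of a number 66 percentage points higher from compound 3 to compound 4 (beyond the scatter).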

Compound 4, a percentage reported as inhibition, at one concentration (the size of the read-out at that concentration, not a potency): 67%
For compound 4 the middle estimate is 8 percentage points above the measured one; the range from low to high includes it.
By their numbers in this assay, from the lowest: compound 3; then compounds 4 and 2 (each within the scatter of the next); then compound 1.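

In this assay, a number 58 percentage points higher from compound 3 to compound 4 (beyond the scatter), so a low reading is not the fate of every group on the sulfonyl sulfur other than 4-methylphenyl, and a second phenyl with a single group now stands well clear of 3,5-difluorophenyl on the shared core. For the compounds shown here, the single group on that phenyl still counts, as a number 26 percentage points lower from compound 1 to compound 4 (beyond the scatter), which gives the first measured difference between two such phenyls and shows that methoxy does not simply stand in for methyl on this read-out. No measurement bearing on either step is at hand, so the data record the size and direction of these changes and offer no account of them.

From the compounds shown here alone, it remains open whether the low reading follows from the fluorines themselves or from the 3,5-difluorophenyl pattern as a whole, and plain phenyl or a phenyl carrying a single fluorine would help to separate the two. Also open, going by these compounds, is how far the trend from methyl to methoxy extends to a longer chain such as ethoxy or to an amine such as dimethylamino on the same phenyl.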